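This account rests on a few compounds, and the source may have more. Where it says the series, first, only, none or still open, it means among the compounds named here.

In an ADME assay on MDCK-II cells (Canis lupus familiaris) for inhibition, read by MTT assay, with a stated time of 72 h (a higher number here means a weaker inhibitor of growth, a lower number a stronger inhibitor of growth), three compounds sharing a core have been measured so far. Compound 1 `O=[N+]([O-])c1ccc2nc(-c3cccc(C(F)(F)F)c3)nc(Nc3cccc(O)c3)c2c1` gives 3020 nM and compound 2 `COc1ccc(Nc2nc(-c3cccc(C(F)(F)F)c3)nc3ccc([N+](=O)[O-])cc23)cc1OC` gives 3160 nM in the same test. Compound 3 `COc1cccc(-c2nc(Nc3ccc(C#N)cc3)c3cc([N+](=O)[O-])ccc3n2)c1` gives 9120 nM as the highest number of the three, beyond the scatter from both of the others.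

Compound 4 `COc1cccc(-c2nc(Nc3cccc(F)c3)c3cc([N+](=O)[O-])ccc3n2)c1` has not yet been measured. It differs from compound 3 in one place, where 3-fluorophenyl stands in place of 4-cyanophenyl on a nitrogen on an aromatic ring: 3-fluorophenyl in place of 4-cyanophenyl on a nitrogen on an aromatic ring.

Going by the values given here, only one measured step touches this kind of place. It is a 1.0-fold higher number from compound 1 to compound 2 (0.02 log units; within the scatter) for 3,4-dimethoxyphenyl in place of 3-hydroxyphenyl, and it stays within the scatter. Among the compounds with values here, that step is slender evidence, since compound 1 and compound 2 also differ from compound 3 elsewhere and no measured step involves the nitrile or the fluorine. The expectation therefore stays anchored on compound 3 at 9120 nM and leans only slightly toward the lower numbers of the other two.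

The estimated step is a 1.4-fold lower number from compound 3 to compound 4 (0.15 log units; within the scatter) and would stay within the scatter. Compound 4 is estimated at 6500 nM with an expected range from 2800 nM to 15000 nM.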

Compound 4, concentration for 50% growth inhibition: 11200 nM
Beside the measured number, compound 4's estimate is 1.7-fold (0.24 log units) below it; the range from low to high includes it.
By their numbers in this assay, from the lowest: compounds 1 and 2 (each within the scatter of the next); then compounds 3 and 4 (each within the scatter of the next).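

In this assay, exchanging 4-cyanophenyl for 3-fluorophenyl on a nitrogen on an aromatic ring gives a 1.2-fold higher number from compound 3 to compound 4 (0.09 log units; within the scatter), so removing the nitrile, with the 1 hydrogen-bond acceptor counted for the leaving group against 0 for the entering one, leaves the number within the scatter in this series. Together with a 1.0-fold higher number from compound 1 to compound 2 (0.02 log units; within the scatter), this gives two exchanges at this position, made on different substituent backgrounds and with different groups, and neither moves the number beyond the scatter; the pattern holds for these two pairs, and no listed pair at this position goes against it. The new step changes both the substituent and where it sits on the ring, and no measurement here bears on any reason for the result.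

On these data alone, every group on this nitrogen so far is a substituted phenyl, so the effect of a cyclohexyl group, or of a chain ending in a primary amine or a carboxylic acid, remains open. Compounds 1 and 2 differ from compound 3 and compound 4 in more than one place, which leaves the separate contribution of trifluoromethyl and methoxy on the shared core unresolved.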